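Removing the amino group: from compound 2 to compound 3

The compounds below may be only part of what the source reports. "The series", "measured", "known", "first", "only" and "open" are said of these compounds alone.

Measured compounds:
compound 1 `Cc1ccc2nc(C(=O)c3ccc(F)c(O)c3)ccc2c1` — 6 nM
compound 2 `Nc1ccc2ccc(C(=O)c3ccc(F)c(O)c3)nc2c1` — 34 nM

In an assay for binding affinity to 17-beta-hydroxysteroid dehydrogenase 14 (Homo sapiens), read by fluorescence, with a stated time of 15 min, in the presence of a further agent that is not named here (on this read-out higher numbers stand for weaker inhibition and lower numbers for stronger inhibition), compound 2 gives the higher of the two numbers, and compound 1 sits at a lower value, a gap beyond the usual scatter. Compound 3 `O=C(c1ccc(F)c(O)c1)c1ccc2ccccc2n1` differs from compound 2 in one place: hydrogen in place of amino on an aromatic carbon. Among the measured compounds shown here, no measured pair shows this exact change, so compound 1 is the only guide. A modest step toward lower numbers is expected here. Compound 3 is estimated at 12 nM with a range of 4 nM to 40 nM. This estimate implies an expected step of a 2.8-fold lower number from compound 2 to compound 3 (0.45 log units; beyond the scatter).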

Compound 3, inhibition constant in the 17-beta-hydroxysteroid dehydrogenase 14 assay: 12 nM
The estimate for compound 3 equals the measured number at the digits printed; measured number inside the range.
By their numbers in the 17-beta-hydroxysteroid dehydrogenase 14 assay, from the lowest: compounds 1 and 3 (each within the scatter of the next); then compound 2.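

In the 17-beta-hydroxysteroid dehydrogenase 14 assay, the amino group proves no asset on this aromatic carbon: hydrogen in its place gives a 2.8-fold lower number from compound 2 to compound 3 (0.45 log units; beyond the scatter). The methyl group of compound 1 shows no readable gain over hydrogen, since replacing it gives a 2.0-fold higher number from compound 1 to compound 3 (0.30 log units; within the scatter). In a physicochemical assay for solubility, in phosphate buffer, with a stated time of 24 h, at pH 7.4, tested at 200 uM (a higher number here means a more soluble compound, a lower number a less soluble compound), compound 2 gives > 200000 nM as a limit of the assay. In the physicochemical assay compound 3 gives > 200000 nM as a limit of the assay. The step between the amino and hydrogen compounds in the physicochemical assay cannot be read: the limit of > 200000 nM in the physicochemical assay, at which 2 of the 2 values shown sit.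

Left open is how a methoxy group or a carboxylic acid on this aromatic carbon would read in the 17-beta-hydroxysteroid dehydrogenase 14 assay. Also open, on these data alone, is how far the amino and hydrogen compounds lie beyond that limit in the physicochemical assay.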